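The source may report more compounds than this note shows. Statements on the series, on what has been measured and on what is new or still open speak of the compounds shown alone.

Three compounds share one core here. Going by the values given here, in a functional assay on EJ cells (Homo sapiens) for cytotoxicity, with a stated time of 48 h (on this read-out lower numbers stand for stronger inhibition of growth and higher numbers for weaker inhibition of growth), compound 1 `Nc1nc(NC2CCCCC2)cc(-c2cc(N3C[C@H](O)[C@@H](O)C3)ccc2O)n1` gives 2000 nM, the only number available. Among the compounds with values here, for compound 2 `Nc1nc(-c2cc(N3C[C@H](O)[C@@H](O)C3)ccc2O)cc(C2CCNCC2)n1` the entry reads "not determined" (no result reported), so compound 2 has no place on the scale and no step from it can be measured. Compound 3 `CCc1cc(-c2cc(N3C[C@H](O)[C@@H](O)C3)ccc2O)nc(N)n1` carries ethyl in place of piperidin-4-yl on an aromatic carbon. In this assay the expectation rests only on compound 1 at 2000 nM, with a modest step from that value towards weaker growth inhibition. The estimated value for compound 3 is 3000 nM, with an expected range of 700 nM to 12000 nM.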

Compound 3, concentration for 50% growth inhibition: 1500 nM
Beside the measured number, compound 3's estimate is 2.0-fold (0.30 log units) above it, and the stated range covers the measured number.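

In this assay, ethyl in place of cyclohexylamino on this aromatic carbon gives a 1.3-fold lower number from compound 1 to compound 3 (0.12 log units; within the scatter), so this change leaves growth inhibition unchanged within the usual scatter. At this position, then, the ring of cyclohexylamino is not needed to keep this level of growth inhibition. No measured evidence explains this result.

Steps involving compound 2 cannot be read, so the effect of piperidin-4-yl here remains unknown. Also open, as far as these compounds go, is whether a longer chain, such as hexyl, or a carboxylic acid at this position would shift the value.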